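The compounds below may be only part of what the source reports. "The series", "measured", "known", "first", "only" and "open" are said of these compounds alone.

In a functional assay on BJAB cells (Homo sapiens) for antiproliferative activity, with a stated time of 4 days (on this read-out higher numbers stand for an effect only at larger amounts of compound and lower numbers for an effect already at smaller amounts), the measured compounds are:

Compound 1 `CCSc1sc(-n2nc(C)c(Cc3ccccc3[N+](=O)[O-])c2C(=O)O)nc1-c1ccc(Cl)c(Cl)c1` gives 59000 nM
Compound 2 `Cc1nn(-c2nc(-c3ccc(Cl)c(Cl)c3)c(SC(C)C)s2)c(C(=O)O)c1-c1ccc(Cl)cc1` gives 2500 nM
Compound 3 `Cc1c(-c2cc(Cl)cc(Cl)c2)c(C(=O)O)nn1-c1nc(-c2ccncc2)c(SC(C)C)s1` gives "not active" (no number reported), reported without a number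

Compound 2 has the lowest number of the two reported; compound 1 lies well higher, by a gap beyond the usual scatter, and compound 3 gives no number at all. Compound 4 `Cc1nn(-c2nc(-c3ccc(Cl)c(Cl)c3)c(SC(C)C)s2)c(C(=O)O)c1-c1cccnc1` has not been measured. It differs from compound 2 in one place: pyridin-3-yl in place of 4-chlorophenyl on an aromatic carbon. Going by the values given here, no measured pair shows this same change, so there is no step to lean on. With a ring nitrogen entering in place of a chlorine, a modest rise in this assay is expected, a 2.4-fold higher number from compound 2 to compound 4 (0.38 log units; beyond the scatter), not a large one. Compound 4 is therefore estimated at 6000 nM, with a likely range from 2000 nM to 25000 nM.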

Compound 4, half-maximal effective concentration: 12000 nM
For compound 4 the middle estimate is 2.0-fold (0.30 log units) below the measured one, within the range that was stated.
By their numbers in this assay, from the lowest: compound 2; then compound 4; then compound 1.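

Putting pyridin-3-yl in place of 4-chlorophenyl, on the aromatic carbon next to the ring atom that bears a carboxy group, brings a 4.8-fold higher number from compound 2 to compound 4 (0.68 log units; beyond the scatter) in this assay. Going by these compounds alone, this is the first measured single change at this position, and it shows that the effect survives the swap, but only at larger amounts of compound. Nothing given here explains the rise. On these data alone, what stays open is how a 4-aminophenyl or a 4-methoxyphenyl group would behave at this place, and whether a different placing of the ring nitrogen, as in pyridin-4-yl, would give a lower or higher number.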